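Swapping chloro for methoxy on three inactive cinnamoyl analogues

The source may report more compounds than this note shows. Statements on the series, on what has been measured and on what is new or still open speak of the compounds shown alone.

Compound 1 `O=C(/C=C/c1cccc(Cl)c1)c1nc2ccccc2s1`: > 100000 nM
Compound 2 `OC(/C=C/c1cccc(Cl)c1)c1nc2ccccc2[nH]1`: > 100000 nM
Compound 3 `COc1cccc(/C=C/C(O)c2nc3ccccc3[nH]2)c1`: > 100000 nM

Three compounds were tested in a functional assay on HCT-116 cells (Homo sapiens) for antiproliferative activity, read by MTT assay, with a stated time of 48 h; on this read-out higher numbers stand for weaker inhibition and lower numbers for stronger inhibition. In this assay compound 1 gives > 100000 nM, which is a limit of the assay and not a number. Compound 2 gives > 100000 nM, again a limit. Compound 3 gives > 100000 nM, also a limit. The difference between the core of compound 1 and the core of compound 2 is not broken down here.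

From compound 2 to compound 3 the change is methoxy in place of chloro on an aromatic carbon. The size of that step is a step that the two limits leave unreadable from compound 2 to compound 3, because the limit of > 100000 nM in this assay, at which 3 of the 3 values shown sit, holds both values.

Compound 4 `COc1cccc(/C=C/C(=O)c2nc3ccccc3s2)c1` is not yet measured. From compound 1 to compound 4 the change is methoxy in place of chloro on an aromatic carbon, the same change as the one just described. For compound 4 the expected step is a step that the limit leaves unreadable from compound 1 to compound 4, an expectation that rests on a step that the two limits leave unreadable from compound 2 to compound 3 and on (the limit of > 100000 nM in this assay, at which 3 of the 3 values shown sit). On that basis the estimate for compound 4 in this assay is 150000 nM, with an expected range from 40000 nM to 600000 nM.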

Compound 4, half-maximal inhibitory concentration: > 100000 nM
Compound 4 was reported as a limit; the forecaster's own chance of this, stated with the estimate: 80%; the middle value is on the limit's open side.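

No size can be read for the step from chloro to methoxy between compound 1 and compound 4, because both values are limits and not numbers: the limit of > 100000 nM in this assay, at which 4 of the 4 values shown sit.

The compounds shown leave open whether methoxy in place of chloro changes anything in this assay and which structure, if any, would give a measurable value there.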